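A smaller group on the ring nitrogen of compound 2

The compounds below may be only part of what the source reports. "The series", "measured", "known", "first", "only" and "open" are said of these compounds alone.

Of the compounds shown here, three sharing one core have been measured in a functional assay on MGC-803 cells (Homo sapiens) for antiproliferative activity, read by CCK-8 assay, with a stated time of 72 h, tested at 8 uM; a higher number here means a stronger effect of the compound at the concentration tested, a lower number a weaker effect. Compound 1 `Nc1ccccc1NC(=O)c1ccc(CSC(=S)N2CCc3ccc([N+](=O)[O-])cc32)cc1` gives 39.6%. Compound 3 `Nc1ccccc1NC(=O)c1ccc(CSC(=S)N(Cc2ccccc2)Cc2ccccc2)cc1` gives 30.7%. Compound 2 `COc1ccc(N2CCN(C(=S)SCc3ccc(C(=O)Nc4ccccc4N)cc3)CC2)cc1` gives 22.9%. Among these three numbers compound 2 stands lowest. Its gap to compound 3 lies within the usual scatter, so these two cannot be ordered against each other, whereas its gap to compound 1 lies beyond the scatter, so compound 1 shows the stronger effect of that pair.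

Compound 4 `CN1CCN(C(=S)SCc2ccc(C(=O)Nc3ccccc3N)cc2)CC1` differs from compound 2 in one place: methyl in place of 4-methoxyphenyl on an amine nitrogen in a ring. Among the compounds with values here, no pair of measured compounds isolates a change of this kind, so nothing in the data anchors the size of the resulting step. All three measured compounds carry a large group on the amine nitrogen, and their readings in this assay spread only over a moderate span, with the differing groups on that nitrogen not separating them sharply. The step expected in this assay is therefore modest, a number 1.1 percentage points higher from compound 2 to compound 4 (within the scatter), and is not expected to lie clearly beyond the scatter in either direction. Compound 4 is accordingly estimated at 24%, with a range from 8% to 42%.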

Compound 4, a percentage reported as inhibition, at one concentration (the size of the read-out at that concentration, not a potency): 84.4%
Compound 4: middle estimate off by 60.4 percentage points, on the low side, outside the stated range (above it).
By their numbers in this assay, from the lowest: compounds 2, 3 and 1 (each within the scatter of the next, the first and the last beyond it); then compound 4.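

In this assay, methyl in place of 4-methoxyphenyl on the amine nitrogen in the ring gives a number 61.5 percentage points higher from compound 2 to compound 4 (beyond the scatter), so the read-out at this position depends strongly on the group it carries. Within the data shown here, the earlier compounds offered no step that differed in one place, and this pair is the first to show that a change at this nitrogen alone can move the number so far: the group that leaves has 8 heavy atoms and one six-membered aromatic ring, while the group that enters has 1 heavy atom and no ring. No evidence is at hand that bears on why the step is this large.

Among these compounds, the single pair does not separate the loss of the aromatic ring from the loss of the methoxy oxygen or from the drop in heavy atoms, and it does not show how the read-out would respond to an ethyl group, an unsubstituted phenyl ring or a hydrogen on the same nitrogen. Going by these compounds, the read-out also comes from one concentration, so how compound 4 and compound 2 differ in potency remains open.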